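This account rests on a few compounds, and the source may have more. Where it says the series, first, only, none or still open, it means among the compounds named here.

Compound 1: `CCc1cc(C(C)=O)c(O)cc1OCCCCCC(C)(C)C(=O)O`, giving 73%. Compound 2: `CCc1cc(C(C)=O)c(O)cc1OCCCCCC(C)(C)c1nnnn1C`, giving 59%. Compound 3: `CCc1cc(C(C)=O)c(O)cc1OCCCCCC[S+](C)[O-]`, not yet measured.

In an assay on isolated protein for binding affinity to leukotriene B4 receptor 1 (Homo sapiens), tested at 1 uM (on this read-out higher numbers stand for more inhibition at the one concentration tested (going by the name of the read-out) and lower numbers for less inhibition), compound 2 stands lowest of the two numbers; its nearest neighbour is compound 1, and the step of a number 14 percentage points lower from compound 1 to compound 2 (beyond the scatter) was modest yet beyond the scatter. Compound 3 differs from compound 2 by a group of 4 heavy atoms (2 carbon, 1 oxygen, 1 sulfur; no ring) in place of a group of 9 heavy atoms (5 carbon, 4 nitrogen; one five-membered aromatic ring with 4 hetero atoms), on a saturated chain carbon, five bonds along the chain from an oxygen on an aromatic ring. For the measured compounds named here, no measured step matches this change; the single measured step, a number 14 percentage points lower from compound 1 to compound 2 (beyond the scatter), concerns a different exchange at the same chain carbon, so it guides only loosely. A further modest drop is expected, a number 14 percentage points lower from compound 2 to compound 3 (beyond the scatter). Compound 3 is estimated at 45%, within 20% to 70%.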

Compound 3, a percentage reported as inhibition, at one concentration (the size of the read-out at that concentration, not a potency): 50%
For compound 3 the middle estimate is 5 percentage points below the measured one; the measured number falls inside the stated range.
By their numbers in this assay, from the lowest: compounds 3 and 2 (each within the scatter of the next); then compound 1.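

With a far smaller, ringless group of 4 heavy atoms holding sulfur and oxygen in place of the tetrazole-bearing group, the step is a number 9 percentage points lower from compound 2 to compound 3 (within the scatter) in this assay, so the two groups cannot be told apart here. The step of a number 23 percentage points lower from compound 1 to compound 3 (beyond the scatter) shows that this second replacement for the carboxy-bearing group also falls short of compound 1 by more than the scatter. No evidence is available to explain these numbers. Going by these compounds, whether an amine at this place would come closer to compound 1 remains open.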